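A Second Decyloxy Chain on the Core of Compound 1

The source may report more compounds than this note shows. Statements on the series, on what has been measured and on what is new or still open speak of the compounds shown alone.

Among the compounds with values here, compound 1 `CCCCCCCCCCOc1cccc(OCCCCCC(=O)N(Cc2ccc(C(=O)O)cc2)c2cccc(C(=O)O)c2)c1` is the only compound with a number: in an assay on isolated protein for binding affinity to P-selectin (Homo sapiens), read by ELISA, tested at 500 uM (on this read-out higher numbers stand for more inhibition at the one concentration tested (going by the name of the read-out) and lower numbers for less inhibition), compound 1 gives 103%. For compound 2 `CCCCCCCCCCOc1cccc(OCCCCCC(=O)N(Cc2ccc(C(=O)O)cc2)c2ccc(C(=O)O)cc2)c1` the outcome in this assay is "not determined" (no result reported). Compound 3 `CCCCCCCCCCOc1cc(OCCCCCCCCCC)cc(OCCCCCC(=O)N(Cc2ccc(C(=O)O)cc2)c2cccc(C(=O)O)c2)c1` differs from compound 1 by decyloxy in place of hydrogen on an aromatic carbon. Within the data shown here, no step between two measured compounds exists, so the expectation rests on compound 1 alone. The step of a number 8 percentage points lower from compound 1 to compound 3 (within the scatter) is expected to stay within the usual scatter, with at most a small fall. In this assay compound 3 is therefore estimated at 95%, within a range from 70% to 105%.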

Compound 3, a percentage reported as inhibition, at one concentration (the size of the read-out at that concentration, not a potency): 95%
For compound 3 middle estimate and measured number coincide at the digits printed; the range from low to high includes it.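

On the aromatic carbon meta to a decyloxy group, a second decyloxy in place of hydrogen gives, in this assay, a number 8 percentage points lower from compound 1 to compound 3 (within the scatter). The core of compound 1 therefore carries this added chain at this position with no difference beyond the scatter, which a single compound could not show. Nothing available explains this outcome. As far as these compounds go, whether methoxy, an amine or a carboxylic acid on the same carbon would read alike stays open. So does whether compound 1 and compound 3 would still match at lower concentrations.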